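Nitro in Place of Methyl: A Question of Tolerance

The source may report more compounds than this note shows. Statements on the series, on what has been measured and on what is new or still open speak of the compounds shown alone.

Of the compounds shown here, two have been measured in an ADME assay on MDBK cells (Bos taurus) for cytotoxicity, read by MTT assay, with a stated time of 96 h; a higher number here means that more compound is tolerated, a lower number that less compound is tolerated. Compound 1 (`Cc1ccc(/N=N/N(C)c2ccccc2)cc1`) gives > 100000 nM, a limit of the assay. Compound 2 (`Cc1ccc(/N=N/c2ccc(NCCCN(C)C)cc2)cc1`) gives > 100000 nM, also a limit of the assay. Compound 2 thus has no exact number: its place is the limit of > 100000 nM in this assay, at which 2 of the 2 values shown sit. Compound 3 (`CN(C)CCCNc1ccc(/N=N/c2ccc([N+](=O)[O-])cc2)cc1`) carries nitro in place of methyl on an aromatic carbon, para to a large group: nitro in place of methyl on an aromatic carbon. Among the compounds with values here, no measured step shows what such a change does. A modest move toward less compound tolerated is expected, an at least 1.4-fold lower number from compound 2 to compound 3 (0.15 log units; that floor lies within the scatter). The estimate for compound 3 is 70000 nM, with an expected range of 20000 nM to 100000 nM.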

Compound 3, half-maximal cytotoxic concentration: > 100000 nM
Compound 3 ended at the assay's limit; the forecaster's own chance of this, stated with the estimate: 50%; middle value at least 1.4-fold (0.15 log units) away from the limit.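

Compound 2 and compound 3 both stand at a limit, so no step between them can be read in this assay: the limit of > 100000 nM in this assay, at which 3 of the 3 values shown sit.

The compounds shown leave open whether nitro in place of methyl on an aromatic carbon changes how much compound is tolerated.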